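The compounds below may be only part of what the source reports. "The series", "measured", "known", "first", "only" and "open" are said of these compounds alone.

Measured in an ADME assay on MDBK cells (Bos taurus) for cytotoxicity, read by MTT assay, with a stated time of 96 h; on this read-out higher numbers stand for lower toxicity in this test and lower numbers for higher toxicity in this test:
- compound 1 `FC(F)(F)c1cccc(NC(=S)Nc2ccc(I)cc2)c1`: 9500 nM
- compound 2 `CCCC[C@H]1CC[C@H](c2ccc(NC(=S)Nc3cccc(C(F)(F)F)c3)cc2)CC1`: 10000 nM
- compound 3 `Fc1ccc(NC(=S)Nc2cccc(C(F)(F)F)c2)cc1Cl`: 11000 nM

At 11000 nM, compound 3 cannot be told apart from compound 1 or compound 2, since all three values lie within the usual scatter of each other. The next compound to be tested is compound 4 `Fc1ccc(NC(=S)Nc2cccc(C(F)(F)F)c2)cc1`, which has hydrogen in place of chloro on an aromatic carbon, ortho to a fluoro group: hydrogen in place of chloro on an aromatic carbon.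

Only one measured step links two of these compounds in a single place: a 1.1-fold higher number from compound 1 to compound 2 (0.02 log units; within the scatter). It puts 4-butylcyclohexyl in place of iodo on an aromatic carbon, and it stays within the scatter. Among the compounds with values here, no measured step removes a chloro, so this step offers only indirect guidance. Even so, nothing in the data points to a real shift in this assay, and no change beyond the scatter is expected.

The expected step is a 1.1-fold higher number from compound 3 to compound 4 (0.04 log units; within the scatter). For compound 4 the estimated value is 12000 nM, with an expected range from 6000 nM to 30000 nM.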

Compound 4, half-maximal cytotoxic concentration: 41000 nM
Compound 4: the middle estimate sits 3.4-fold (0.53 log units) below what was measured, outside the stated range (above it).
By their numbers in this assay, from the lowest: compounds 1, 2 and 3 (each within the scatter of the next); then compound 4.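

In this assay, within the data shown here, the loss of the chloro, with hydrogen entering on the aromatic carbon ortho to a fluoro group, gives a 3.7-fold higher number from compound 3 to compound 4 (0.57 log units; beyond the scatter) and so, unlike the one earlier step, lies beyond the scatter. Fluoro in place of iodo gives a 4.3-fold higher number from compound 1 to compound 4 (0.64 log units; beyond the scatter) and fluoro in place of 4-butylcyclohexyl gives a 4.1-fold higher number from compound 2 to compound 4 (0.61 log units; beyond the scatter) as well, so compound 4 stands apart from all three earlier compounds, which cannot be told apart from one another. No measurement is available that bears on why the number rises. Only hydrogen has been shown replacing the chloro, so it stays open whether a bromo, a methyl or a methoxy on that carbon would keep the number near that of compound 3 or move it towards that of compound 4.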